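The source may report more compounds than this note shows. Statements on the series, on what has been measured and on what is new or still open speak of the compounds shown alone.

Working notes on the series. In a functional assay on HeLa cells (Homo sapiens) for cytotoxicity, read by WST assay, with a stated time of 48 h (a higher number here means a weaker inhibitor, a lower number a stronger inhibitor), compound 1 (`COc1cccc(/C=C/C[C@H]2C[C@@H]([C@@H](O)c3ccccc3)CO[C@@H]2c2ccccc2)c1`) gives 10900 nM, compound 2 (`O=[N+]([O-])c1cccc(/C=C/C[C@H]2C[C@@H]([C@@H](O)c3ccccc3)CO[C@@H]2c2ccccc2)c1`) gives 7850 nM and compound 3 (`Oc1cccc(/C=C/C[C@H]2C[C@@H]([C@@H](O)c3ccccc3)CO[C@@H]2c2ccccc2)c1`) gives 18600 nM. Compound 3 stands at the upper end of this narrow range, a place it shares with compound 1: a 1.7-fold higher number from compound 1 to compound 3 (0.23 log units; within the scatter), whereas a 2.4-fold higher number from compound 2 to compound 3 (0.37 log units; beyond the scatter).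

Compound 4 (`O[C@@H](c1ccccc1)[C@H]1CO[C@H](c2ccccc2)[C@@H](C/C=C/c2cccnc2)C1`) carries pyridin-3-yl in place of 3-hydroxyphenyl on a double-bonded chain carbon bound to a double-bonded chain carbon. Among the compounds with values here, no measured step makes this exchange. The nearest evidence comes from the substituent swaps on the aromatic ring at the end of the same chain, which are small: a 1.4-fold lower number from compound 1 to compound 2 (0.14 log units; within the scatter), and the largest is a 2.4-fold higher number from compound 2 to compound 3 (0.37 log units; beyond the scatter). A step beyond the scatter is therefore not expected in this assay. The estimated step is a 1.3-fold lower number from compound 3 to compound 4 (0.12 log units; within the scatter). For compound 4 the expected value is 14000 nM, with an estimated range of 6500 nM to 30000 nM.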

Compound 4, half-maximal inhibitory concentration: > 100000 nM
Compound 4: no number, only a limit; the forecaster's own chance of this, stated with the estimate: 10%; at least 7.1-fold (0.85 log units) between middle value and limit.
By their numbers in this assay, from the lowest: compounds 2, 1 and 3 (each within the scatter of the next, the first and the last beyond it). At a limit, above all of these: compound 4.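

In this assay compound 4 is recorded only as a limit, not as a number: the limit of > 100000 nM in this assay, at which 1 of the 4 values shown sits. Exchanges among the substituents on the phenyl ring moved the number by no more than a 2.4-fold higher number from compound 2 to compound 3 (0.37 log units; beyond the scatter), whereas pyridin-3-yl at the same place gives an at least 5.3-fold higher number from compound 3 to compound 4 (0.73 log units; beyond the scatter), an at least 9.1-fold higher number from compound 1 to compound 4 (0.96 log units; beyond the scatter) and an at least 12-fold higher number from compound 2 to compound 4 (1.10 log units; beyond the scatter). The change of the ring itself at this place therefore matters more here than any of the substituent swaps, with compounds 1, 2 and 3 in one narrow range and compound 4 outside it.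

The compounds shown cannot separate the effect of the ring nitrogen from the loss of the substituent, since the exchange changes both at once. An unsubstituted phenyl group would divide the two, and 3-aminophenyl would extend the substituent set.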